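A few compounds are considered here, and "the series" means these few. Any claim that something is new, unique, unknown or untested is made for them only; others in the source may bear on it.

In a physicochemical assay for solubility, measured as thermodynamic solubility, at pH 7.4 (a lower number here means a less soluble compound, a higher number a more soluble compound), compound 1 `CC(C)Oc1cc(-c2cncc(-c3cnn(C4COC4)c3)c2)ccc1C(N)=O` gives 28 ug/mL, compound 2 `Cc1[nH]ncc1-c1cncc(-c2ccc(C(N)=O)c(OC(C)C)c2)c1` gives 11 ug/mL and compound 3 `Cc1c(-c2cncc(-c3ccc(C(N)=O)c(OC(C)C)c3)c2)cnn1C` gives 7.3 ug/mL. Compound 3 belongs to the low pair of the series: the top value stands apart by a 3.8-fold lower number from compound 1 to compound 3 (0.58 log units; beyond the scatter), and within the pair there is a 1.5-fold lower number from compound 2 to compound 3 (0.18 log units; within the scatter). Compound 4 `CC(C)Oc1cc(-c2cccnc2)ccc1C(N)=O` follows through (hydrogen in place of 1,5-dimethyl-1H-pyrazol-4-yl on an aromatic carbon), hydrogen in place of 1,5-dimethyl-1H-pyrazol-4-yl on an aromatic carbon. The measured steps only exchange one pyrazol-4-yl group for another, as in a 2.5-fold lower number from compound 1 to compound 2 (0.41 log units; beyond the scatter), and none removes the group. They therefore offer only a rough scale, and a modest rise in this assay is a tentative expectation. The expected step is a 3.4-fold higher number from compound 3 to compound 4 (0.53 log units; beyond the scatter). Compound 4 is estimated at 25 ug/mL, with an expected range of 8 ug/mL to 80 ug/mL.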

Compound 4, solubility: 45 ug/mL
Compound 4: middle estimate off by 1.8-fold (0.26 log units), on the low side; measured number inside the range.
By their numbers in this assay, from the lowest: compounds 3 and 2 (each within the scatter of the next); then compounds 1 and 4 (each within the scatter of the next).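

In this assay the position on the aromatic carbon can now be read with no pyrazole at all: hydrogen in place of the 1,5-dimethyl group gives (a 6.2-fold higher number from compound 3 to compound 4 (0.79 log units; beyond the scatter)), and hydrogen in place of 5-methyl-1H-pyrazol-4-yl gives (a 4.1-fold higher number from compound 2 to compound 4 (0.61 log units; beyond the scatter)). Against the 1-(oxetan-3-yl) pyrazole, hydrogen gives only (a 1.6-fold higher number from compound 1 to compound 4 (0.21 log units; within the scatter)), so that group alone among the three stands within the scatter of the unsubstituted compound. Nothing available explains these steps. Open, as far as these compounds go, is how a non-aromatic group at this position, such as an amine or a morpholine, or a carboxylic acid, would compare with hydrogen. Also open, from the compounds shown here alone, is whether oxetan-3-yl on the nitrogen of the 5-methyl pyrazole would give a number like that of compound 1.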